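Replacing 4-methoxyphenyl with pyridin-3-yl: an expected antiproliferative value

The source may report more compounds than this note shows. Statements on the series, on what has been measured and on what is new or still open speak of the compounds shown alone.

In a functional assay on BJAB cells (Homo sapiens) for antiproliferative activity, with a stated time of 4 days (a higher number here means that more compound is needed for the effect, a lower number that less compound is needed), three compounds have been measured so far:

Compound 1 `COc1ccc(-c2c(C)nn(-c3nc(-c4ccc(Cl)c(Cl)c4)c(SC(C)C)s3)c2C(=O)O)cc1` gives 2100 nM.
Compound 2 `Cc1nn(-c2nc(-c3ccc(Cl)c(Cl)c3)c(SC(C)C)s2)c(C(=O)O)c1-c1cnccn1` gives 14000 nM.
Compound 3 `Cc1nn(-c2nc(-c3ccc(Cl)c(Cl)c3)c(SC(C)C)s2)c(C(=O)O)c1-c1ccncc1` gives 5900 nM.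

Compound 1 stands at the lowest number of the three, so it needs the least compound for the effect; compound 3 comes nearest and compound 2 is furthest away. The unmeasured compound 4 `Cc1nn(-c2nc(-c3ccc(Cl)c(Cl)c3)c(SC(C)C)s2)c(C(=O)O)c1-c1cccnc1` differs from compound 1 in one place: pyridin-3-yl in place of 4-methoxyphenyl on an aromatic carbon.

Among the compounds with values here, two measured steps bear on this change. Each of them also replaces 4-methoxyphenyl with a ring that carries nitrogen at the same place on the shared core. The step of a 2.8-fold higher number from compound 1 to compound 3 (0.45 log units; beyond the scatter) and the step of a 6.7-fold higher number from compound 1 to compound 2 (0.82 log units; beyond the scatter) both raised the number, by modest but real amounts. The step of a 2.4-fold lower number from compound 2 to compound 3 (0.38 log units; beyond the scatter) shows that the size of the rise depends on which ring enters. Pyridin-3-yl is closest in kind to pyridin-4-yl, so a rise of similar, modest size is expected, a 3.3-fold higher number from compound 1 to compound 4 (0.52 log units; beyond the scatter).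

Compound 4 is therefore estimated at 7000 nM in this assay, with a likely range from 3000 nM to 18000 nM.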

Compound 4, half-maximal effective concentration: 12000 nM
Estimate against measurement, compound 4: 1.7-fold (0.23 log units) below, and the stated range covers the measured number.
By their numbers in this assay, from the lowest: compound 1; then compound 3; then compounds 4 and 2 (each within the scatter of the next).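

In this assay the two pyridine rings can be told apart, since a 2.0-fold higher number from compound 3 to compound 4 (0.31 log units; beyond the scatter) is a small step but lies beyond the scatter, so it matters which pyridinyl group sits at this place on the shared core. The step of a 1.2-fold lower number from compound 2 to compound 4 (0.07 log units; within the scatter) stays within the scatter, so pyridin-3-yl and pyrazin-2-yl cannot be separated here, although pyridin-4-yl can be separated from both. With a 5.7-fold higher number from compound 1 to compound 4 (0.76 log units; beyond the scatter) as the third such replacement, all three nitrogen-bearing rings shown give a higher number than 4-methoxyphenyl, with no compound here going against that.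

Nothing measured here explains these differences. Also open, going by these compounds, is whether plain phenyl, or a phenyl ring carrying an amine, would bring the number back towards the value of compound 1 at 2100 nM or leave it near those of the nitrogen-bearing rings.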